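Hydroxylation of the lactam ring in the shared core

This account rests on a few compounds, and the source may have more. Where it says the series, first, only, none or still open, it means among the compounds named here.

Measured compounds:
compound 1 `CO[C@@H](C(=O)N[C@@H]1CCCCNC1=O)[C@H](O)[C@@H](O)[C@H](O)/C=C/C(C)(C)C` — 1100 nM
compound 2 `CO[C@@H](C(=O)N[C@@H]1CCCCNC1=O)[C@@H]1OC(C)(C)O[C@H](/C=C/C(C)(C)C)[C@@H]1O` — > 150000 nM

Among the measured compounds shown here, in a functional assay on KB cells (Homo sapiens) for cytotoxicity, read by colorimetric assay and neutral red uptake, with a stated time of 72 h (on this read-out higher numbers stand for weaker inhibition and lower numbers for stronger inhibition), compound 1 gives 1100 nM and is the only compound of the pair with a number rather than a limit. For compound 2 this assay returns only a limit, > 150000 nM. The remaining entry in the set is therefore (the limit of > 150000 nM in this assay, at which 1 of the 2 values shown sits). For the measured compounds named here, because only one number exists, no measured step between compounds that differ in a single place is available, and nothing in the set speaks to the effect of a hydroxy on the lactam ring.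

Compound 3 `CO[C@@H](C(=O)N[C@@H]1CC[C@@H](O)CNC1=O)[C@H](O)[C@@H](O)[C@H](O)/C=C/C(C)(C)C` differs from compound 1 by hydroxy in place of hydrogen on a saturated ring carbon. Going by the values given here, with no comparable measured step, the expected change in this assay from compound 1 to compound 3 is a 1.1-fold lower number from compound 1 to compound 3 (0.04 log units; within the scatter), which is taken as no more than the usual scatter in either direction. Compound 3 is thus estimated at 1000 nM in this assay, with a range from 300 nM to 4000 nM.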

Compound 3, half-maximal inhibitory concentration: 5100 nM
Beside the measured number, compound 3's estimate is 5.1-fold (0.71 log units) below it, outside the stated range (above it).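

Among the compounds shown here, this is the first measured step at this position: in this assay the change from 2-oxoazepan-3-yl to 6-hydroxy-2-oxoazepan-3-yl gives a 4.6-fold higher number from compound 1 to compound 3 (0.67 log units; beyond the scatter) and so weakens inhibition modestly. The position is thus not indifferent to this change, yet compound 3 still returns a number and not a limit, so inhibition in this read-out is weakened without being lost. No measured property among the compounds shown bears on this step.

On these data alone, whether a step of this size holds for the opposite configuration at this carbon, or for an amine or a methoxy on the same ring carbon, remains open. Also open, as far as these compounds go, is whether a hydroxy on another saturated carbon of the ring gives a similar step.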